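The source may hold more compounds than are shown below. What is called first, only, known or untested is meant among the compounds shown, and "the series" means these compounds.

Compound 1 `CCOC(=O)c1cnc(N2CCN(Cc3cccc(C(F)(F)F)c3)CC2)nc1Oc1c(C)cc(-c2ccc(C#N)cc2)cc1C` gives > 125000 nM. Compound 2 `CCOC(=O)c1cnc(N2CCN(Cc3ccccc3F)CC2)nc1Oc1c(C)cc(-c2ccc(C#N)cc2)cc1C` gives > 125000 nM. Compound 3 `CCOC(=O)c1cnc(N2CCN(Cc3ccc(C(N)=O)cc3)CC2)nc1Oc1c(C)cc(-c2ccc(C#N)cc2)cc1C` gives 66500 nM.

In an ADME assay on MT4 cells (Homo sapiens) for cytotoxicity, read by MTT assay, with a stated time of 4 days (a lower number here means that less compound is tolerated, a higher number that more compound is tolerated), the value of compound 1 is a limit of the assay, not a number, namely (the limit of > 125000 nM in this assay, at which 2 of the 3 values shown sit). The value of compound 2 is also a limit. Only compound 3 gives a number. Compound 4 `CCOC(=O)c1ccc(CN2CCN(c3ncc(C(=O)OCC)c(Oc4c(C)cc(-c5ccc(C#N)cc5)cc4C)n3)CC2)cc1` differs from compound 1 by 4-(ethoxycarbonyl)phenyl in place of 3-(trifluoromethyl)phenyl on a saturated chain carbon bound to an amine nitrogen in a ring. Among the measured steps, a step that the two limits leave unreadable from compound 1 to compound 2 cannot be read, while an at least 1.8-fold lower number from compound 1 to compound 3 (0.27 log units; that floor lies within the scatter) and an at least 1.8-fold lower number from compound 2 to compound 3 (0.27 log units; that floor lies within the scatter) are floors lying within the scatter. Within the data shown here, no measured step involves a 4-(ethoxycarbonyl)phenyl, and no step beyond the scatter is expected in this assay. Compound 4 is therefore expected to give 110000 nM (range 50000 nM to 250000 nM), an estimated step of an at least 1.1-fold lower number from compound 1 to compound 4 (0.05 log units; that floor lies within the scatter).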

Compound 4, half-maximal cytotoxic concentration: > 125000 nM
Compound 4 was reported as a limit (the forecaster's own chance of this, stated with the estimate: 55%); at least 1.1-fold (0.05 log units) between middle value and limit.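

In this assay, compound 4 also gives a limit of the assay, not a number: the limit of > 125000 nM in this assay, at which 3 of the 4 values shown sit. Within the 4-substituted benzyl pair, ethoxy in place of amino on the carbonyl carbon gives an at least 1.8-fold higher number from compound 3 to compound 4 (0.27 log units; that floor lies within the scatter), so a 4-(ethoxycarbonyl)phenyl group and a 4-carbamoylphenyl group are not shown to differ beyond the scatter. The steps from compound 1 and from compound 2 to compound 4 cannot be read, since both ends of each are limits.

Going by these compounds, it remains open how far above that limit compound 4 lies. On these data alone, it is also open whether a carboxylic acid or an amine on this phenyl ring would give a number rather than a limit.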